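The compounds below may be only part of what the source reports. "The series", "measured", "known", "first", "only" and "open" are said of these compounds alone.

Measured so far:
- compound 1, `c1ccc(-c2cn3ccnc3c(-c3ccc4ncn(C5CCCCC5)c4c3)n2)cc1`: 22.9%
- compound 2, `c1ccc2c(-c3cn4ccnc4c(-c4ccc5ncn(C6CCCCC6)c5c4)n3)cccc2c1`: 9.08%

Both compounds share one core and differ only in the aryl group on the core. In a functional assay on SNB-19 cells (Homo sapiens) for inhibition, read by sulforhodamine B assay, with a stated time of 48 h, tested at 10 uM (on this read-out higher numbers stand for more inhibition at the one concentration tested (going by the name of the read-out) and lower numbers for less inhibition), compound 1 gives 22.9%, while compound 2 gives 9.08%. For the measured compounds named here, the single measured step, a number 13.8 percentage points lower from compound 1 to compound 2 (beyond the scatter), places compound 2 as the lowest of the two numbers, with compound 1 as its only neighbour, standing beyond the scatter above it.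

Compound 3, `c1cn2cc(-c3ccsc3)nc(-c3ccc4ncn(C5CCCCC5)c4c3)c2n1`, follows from compound 2 by one change: thiophen-3-yl in place of naphthalen-1-yl on an aromatic carbon. Going by the values given here, the only step that bears on this is the one from compound 1 to compound 2, a modest drop when the aryl grew from phenyl to naphthalen-1-yl. Thiophen-3-yl brings the group back to a size nearer phenyl, so a rise from compound 2 of about the same size is expected, a number 10.9 percentage points higher from compound 2 to compound 3 (beyond the scatter). Compound 3 is therefore estimated at 20%, within 5% to 35%.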

Compound 3, a percentage reported as inhibition, at one concentration (the size of the read-out at that concentration, not a potency): 0.39%
Beside the measured number, compound 3's estimate is 19.6 percentage points above it; measured number outside the range, below it.
By their numbers in this assay, from the lowest: compounds 3 and 2 (each within the scatter of the next); then compound 1.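

At this position on the shared core, thiophen-3-yl in place of phenyl also lowers the reading in this assay (a number 22.5 percentage points lower from compound 1 to compound 3 (beyond the scatter)), so phenyl now stands clear of two different replacements, not just the larger naphthalen-1-yl. Thiophen-3-yl and naphthalen-1-yl cannot be told apart here (a number 8.7 percentage points lower from compound 2 to compound 3 (within the scatter)), so across these three compounds the heavy-atom count of the group does not order the numbers, since the smaller thiophen-3-yl does not return to the level of phenyl. Nothing available explains why phenyl stands apart from these two groups.

Going by these compounds, it remains open whether a phenyl carrying an amine, a hydroxyl or a carboxylic acid would match or pass compound 1 22.9% at this position. A single-concentration reading also gives no potency for any of the three compounds.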